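The source may report more compounds than this note shows. Statements on the series, on what has been measured and on what is new or still open speak of the compounds shown alone.

Of the compounds shown here, two sharing one core have been tested in a functional assay on A549 cells (Homo sapiens) for inhibition, read by CCK-8 assay, with a stated time of 48 h; a lower number here means a stronger inhibitor, a higher number a weaker inhibitor. Compound 1 `COc1cc(-c2ccnc3cc(-c4ccc(C(F)(F)F)cc4)nn23)cc(OC)c1OC` gives 2070 nM, and compound 2 `COc1cc(-c2ccnc3cc(-c4ccc5ccn(C)c5c4)nn23)cc(OC)c1OC` gives 829 nM, the lower of the two numbers and so the stronger inhibitor of this pair. The next compound is compound 3 `COc1ccc(-c2cc3nccc(-c4cc(OC)c(OC)c(OC)c4)n3n2)cc1F`, where 3-fluoro-4-methoxyphenyl replaces 1-methyl-1H-indol-6-yl on an aromatic carbon: 3-fluoro-4-methoxyphenyl in place of 1-methyl-1H-indol-6-yl on an aromatic carbon. Among the measured compounds shown here, only one measured step bears on this change, a modest one that brought in the 1-methyl-1H-indol-6-yl group in place of 4-(trifluoromethyl)phenyl: a 2.5-fold lower number from compound 1 to compound 2 (0.40 log units; beyond the scatter). Compound 3 gives that group up again for a substituted phenyl, so a modest move back toward the higher number of compound 1 is expected, although this single step is thin evidence. The expected change is a 1.8-fold higher number from compound 2 to compound 3 (0.26 log units; within the scatter). For compound 3 the estimated value is 1500 nM, with an expected range from 550 nM to 4000 nM.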

Compound 3, half-maximal inhibitory concentration: 545 nM
Beside the measured number, compound 3's estimate is 2.8-fold (0.44 log units) above it; the measured number lies below the stated range.
By their numbers in this assay, from the lowest: compounds 3 and 2 (each within the scatter of the next); then compound 1.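

At this position, on an aromatic carbon next to the ring nitrogen, the two-ring 1-methyl-1H-indol-6-yl group proves not to be required: with the single-ring 3-fluoro-4-methoxyphenyl there is a 1.5-fold lower number from compound 2 to compound 3 (0.18 log units; within the scatter), so this assay does not separate compound 2 from compound 3. Giving up the indole therefore does not return the number to that of compound 1. The two substituted phenyl groups do differ, with a 3.8-fold lower number from compound 1 to compound 3 (0.58 log units; beyond the scatter), which shows that the substituents on the phenyl ring matter here, not merely the presence of a phenyl ring.

The compounds shown leave open whether the fluorine or the methoxy group carries that step, and how a plain 4-methoxyphenyl, or a phenyl bearing an amine or a carboxylic acid, would compare. No measured property is available to explain any of these numbers.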